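The source may hold more compounds than are shown below. What is called first, only, known or untested is meant among the compounds shown, and "the series" means these compounds.

Measured in a functional assay (aorta) with Rattus norvegicus as the target; a higher number here means that more compound is needed for the effect, a lower number that less compound is needed:
compound 1 `COc1ccc(-c2nc(/N=C(\N)NC3CCCCC3)sc2-c2ccc(OC)cc2)cc1`: > 100 uM, a limit
compound 2 `COc1ccc(-c2nc(C(=O)N3CCOCC3)sc2-c2ccc(OC)cc2)cc1`: < 100 uM, a limit

Compound 2 stands only at a limit, < 100 uM, so no number is available for it. Compound 3 `COc1ccc(-c2nc(/C=C/C(=O)O)sc2-c2ccc(OC)cc2)cc1` differs from it as follows: 2-carboxyethenyl in place of (morpholin-4-yl)carbonyl on an aromatic carbon. Among the compounds with values here, the one measured step, a number no higher from compound 1 to compound 2 (the limit leaves the size open), also falls on an aromatic carbon, but its size cannot be read and it gives no direction. No step beyond the scatter is therefore expected in this assay. The expected step is a step that the limit leaves unreadable from compound 2 to compound 3. For compound 3 the estimate is 30 uM, with an expected range of 3 uM to 100 uM.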

Compound 3, concentration for half-maximal effect: 55 uM
Compound 3: middle estimate off by 1.8-fold (0.26 log units), on the low side, within the range that was stated.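

In this assay, within the data shown here, compound 3 gives 55 uM, the first actual number for a group at this aromatic carbon. The values of compound 1 and compound 2 are limits. With the 2-carboxyethenyl group, the series shows an at least 1.8-fold lower number from compound 1 to compound 3 (0.25 log units; that floor lies within the scatter). The step from compound 2 to compound 3 cannot be read because compound 2 stands at a limit: the limit of < 100 uM in this assay, at which 1 of the 3 values shown sits.

Going by these compounds, how much of the value of compound 3 belongs to the carboxylic acid and how much to the ethenyl link stays open. A carboxylic acid set directly on this carbon, or a saturated propanoic acid chain, would separate the two.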